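This account rests on a few compounds, and the source may have more. Where it says the series, first, only, none or still open, it means among the compounds named here.

Measured so far in a functional assay on the whole organism for inhibition, with Rattus norvegicus as the target; on this read-out higher numbers stand for an effect only at larger amounts of compound and lower numbers for an effect already at smaller amounts:
- compound 1 `CC1CC/C(=N\Nc2ccc(F)cc2)c2ncc(C(=O)O)c(=O)n21`: compound 1 gives > 1000 umol/kg, which is a limit of the assay and not a number.
- compound 2 `COc1ccc(N/N=C2\CCC(C)n3c2ncc(C(=O)O)c3=O)cc1`: compound 2 gives 7.6 umol/kg.
- compound 3 `Cc1ccc(N/N=C2\CCC(C)n3c2ncc(C(=O)O)c3=O)cc1`: compound 3 gives > 1000 umol/kg, again a limit and not a number.

Compound 3 therefore stands at the edge of what this assay can see, and it is not alone there: the limit of > 1000 umol/kg in this assay, at which 2 of the 3 values shown sit. Only compound 2 yielded a number, and the step of an at least 130-fold higher number from compound 2 to compound 3 (2.11 log units; beyond the scatter) is large, as is an at least 130-fold lower number from compound 1 to compound 2 (2.11 log units; beyond the scatter). Between fluoro and methyl, a step that the two limits leave unreadable from compound 1 to compound 3.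

Compound 4 `CC(=O)c1ccc(N/N=C2\CCC(C)n3c2ncc(C(=O)O)c3=O)cc1` differs from compound 3 in one place: acetyl in place of methyl on an aromatic carbon. The measured steps that bear on it are the two large ones just named, which show that the group at this position can move the read-out far in either direction; they do not show where acetyl will land, since it matches neither methoxy nor the two groups that sit at the limit. For compound 4 the expected step downward from the limit, of uncertain size, is an at least 10-fold lower number from compound 3 to compound 4 (1.00 log units; beyond the scatter). The estimate for compound 4 in this assay is 100 umol/kg, with a range from 10 umol/kg to 1000 umol/kg.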

Compound 4, dose for 50% inhibition: > 100 umol/kg
Compound 4 gave a limit, no number; the forecaster's own chance of this, stated with the estimate: 40%; the middle value sits exactly at the limit.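

At this place, on an aromatic carbon para to a large group, acetyl joins fluoro and methyl as a third group that yields no number, so methoxy stands alone among the four groups shown in this assay. Acetyl in place of methoxy gives an at least 13-fold higher number from compound 2 to compound 4 (1.11 log units; beyond the scatter) and so gives up the low number seen with methoxy. The result for compound 4 is a limit and not a number, and the steps to it from compound 1 and from compound 3 cannot be read: the limit of > 100 umol/kg in this assay, at which 1 of the 4 values shown sits.

On these data alone, whether the low number belongs to methoxy alone stays open, and an ethoxy group, a hydroxyl or an amine at this place could test that. As far as these compounds go, how far compound 4 truly lies from compound 1 and compound 3 also stays open.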